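Iodo to Methoxy on the Aryl Ring: Working Notes

The compounds below may be only part of what the source reports. "The series", "measured", "known", "first", "only" and "open" are said of these compounds alone.

Values measured in a functional assay on HeLa cells (Homo sapiens) for antiproliferative activity, read by MTT assay, with a stated time of 48 h; a higher number here means a weaker inhibitor, a lower number a stronger inhibitor:
compound 1 `COc1ccc(-c2nn(-c3ccccc3)cc2C(Nc2nc3ccccc3s2)c2c(O)ccc3ccccc23)cc1` gives 9340 nM
compound 2 `Oc1ccc2ccccc2c1C(Nc1nc2ccccc2s1)c1cn(-c2ccccc2)nc1-c1ccc(I)cc1` gives 6590 nM
compound 3 `COc1ccc2nc(NC(c3cn(-c4ccccc4)nc3-c3cccc(I)c3)c3c(O)ccc4ccccc34)sc2c1` gives 6240 nM

Compound 2 and compound 1 differ in one place, (methoxy in place of iodo on an aromatic carbon), and that change gave a 1.4-fold higher number from compound 2 to compound 1 (0.15 log units; within the scatter) in this assay. Compound 3 sits close to compound 2 and compound 1; the difference between the cores of compound 3 and compound 2 is not broken down here.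

Compound 4 `COc1cccc(-c2nn(-c3ccccc3)cc2C(Nc2nc3ccc(OC)cc3s2)c2c(O)ccc3ccccc23)c1` is not yet measured. It differs from compound 3 by methoxy in place of iodo on an aromatic carbon. Among the compounds with values here, this is the same kind of change as the one from compound 2 to compound 1, but not the same: in compound 4 the methoxy sits meta to a large group, whereas in compound 1 it sits para to a large group.

The expectation for compound 4 in this assay rests on the step of a 1.4-fold higher number from compound 2 to compound 1 (0.15 log units; within the scatter), which stayed within the scatter. The step from compound 3 to compound 4 is expected to be a 1.3-fold higher number from compound 3 to compound 4 (0.11 log units; within the scatter). Compound 4 is estimated at 8000 nM, within 4000 nM to 16000 nM.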

Compound 4, half-maximal inhibitory concentration: 10500 nM
Beside the measured number, compound 4's estimate is 1.3-fold (0.12 log units) below it; the range from low to high includes it.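

In this assay, the exchange of 3-iodophenyl for 3-methoxyphenyl gives a 1.7-fold higher number from compound 3 to compound 4 (0.23 log units; within the scatter), a step that does not stand out from repeat measurements. Set beside the earlier case of the same exchange, the two steps agree: the same change on two cores in this assay, a 1.4-fold higher number (0.15 log units; within the scatter) from compound 2 to compound 1 and a 1.7-fold higher number (0.23 log units; within the scatter) from compound 3 to compound 4, 1.2-fold (0.07 log units) apart, within the scatter of two such steps. Within the data shown here, on these two cores, then, the change carries over with no difference that can be told apart, but with only two pairs, and with both steps inside the scatter, this does not show a real effect of methoxy over iodo, nor does it establish a rule for other cores, and any influence of where the group sits cannot be separated from that of the core.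

Still open, going by these compounds, is whether a different group on that aromatic carbon, such as an amine or a carboxylic acid, would give a step beyond the scatter. Also open is whether the exchange would behave alike on a core carrying something other than the groups shown here, for example a longer chain in place of the methoxy.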